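Shortening the ether chain on compound 1

This account rests on a few compounds, and the source may have more. Where it says the series, first, only, none or still open, it means among the compounds named here.

Compound 1 `CCCOCc1cc(O)c(O)c(Br)c1Br` carries the lowest number of the three compounds measured in a functional assay on DLD-1 cells (Homo sapiens) for cytotoxicity, read by MTT assay, with a stated time of 96 h; a higher number here means a weaker inhibitor, a lower number a stronger inhibitor; compound 1 gives 12400 nM. Compound 3 `OCc1cc(Br)c(O)c(O)c1Br` gives 15000 nM, which stands within the scatter of compound 1. Within the data shown here, compound 2 `CCCOCc1cc(O)c(O)c(Br)c1` gives 26300 nM, and the step of a 2.1-fold higher number from compound 1 to compound 2 (0.33 log units; beyond the scatter), hydrogen in place of bromo on an aromatic carbon, is the only measured step beyond the scatter. The unmeasured compound 4 `COCc1cc(O)c(O)c(Br)c1Br` differs from compound 1 by hydrogen in place of ethyl on a saturated chain carbon bound to an oxygen on a saturated carbon. Among the measured compounds shown here, no measured step alters the propoxymethyl group itself; the closest comparison is compound 3, which differs from compound 1 only on that same chain, and the two values stand within the scatter of each other. That comparison offers no reason to expect movement in this assay when the chain is cut from propyl to methyl. Compound 4 is therefore expected to give 14000 nM, with a range from 6000 nM to 32000 nM. The step of a 1.1-fold higher number from compound 1 to compound 4 (0.05 log units; within the scatter) is expected to remain within the scatter.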

Compound 4, half-maximal inhibitory concentration: 14600 nM
For compound 4 the middle estimate is 1.0-fold (0.02 log units) below the measured one, within the range that was stated.
By their numbers in this assay, from the lowest: compounds 1, 4, 3 and 2 (each within the scatter of the next, the first and the last beyond it).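

In this assay, the change from propoxymethyl to methoxymethyl gives the only step shown that stays on the ether chain and leaves the rest of compound 1 untouched: a 1.2-fold higher number from compound 1 to compound 4 (0.07 log units; within the scatter). On these two compounds, propyl and methyl at this place cannot be told apart, whereas the change of hydrogen in place of bromo on an aromatic carbon (a 2.1-fold higher number from compound 1 to compound 2 (0.33 log units; beyond the scatter)) lies beyond the scatter. Nothing measured here explains why the chain change leaves the values within the scatter of each other.

As far as these compounds go, whether a longer chain such as hexyl, or a chain ending in an amine or a carboxylic acid, would also stay within the scatter of compound 1 remains open. Also open, from the compounds shown here alone, is whether methoxymethyl would behave the same way on the core of compound 2, which carries hydrogen in place of one bromo.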